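Shifting a hydroxyl group: from compound 3 to compound 4

The source may hold more compounds than are shown below. What is called first, only, known or untested is meant among the compounds shown, and "the series" means these compounds.

Measured so far:
- compound 1, `Oc1ccc(-c2cc(-c3ccccc3F)cc(-c3ccc(O)cc3)n2)cc1`: 8180 nM
- compound 2, `Oc1ccc(-c2cc(-c3ccccc3C(F)(F)F)cc(-c3ccccc3O)n2)cc1`: 8990 nM
- compound 3, `Oc1ccc(-c2cc(-c3ccccc3C(F)(F)F)cc(-c3cccc(O)c3)n2)cc1`: 5740 nM

All three numbers come from a functional assay on HCT-15 cells (Homo sapiens) for inhibition; on this read-out lower numbers stand for stronger inhibition and higher numbers for weaker inhibition. Compound 3 has the smallest of the three numbers, but its gaps to compound 1 and to compound 2 are both within the usual scatter, so none of the three is set apart from the others.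

Compound 4, `Oc1ccc(-c2cc(-c3ccccc3C(F)(F)F)cc(-c3ccc(O)cc3)n2)cc1`, has not yet been measured. It differs from compound 3 in one place: 4-hydroxyphenyl in place of 3-hydroxyphenyl on an aromatic carbon. Compound 3 and compound 4 share the same atoms, joined differently.

Within the data shown here, one measured step bears on this kind of change, the move of the hydroxyl from one position to another on the same ring: a 1.6-fold lower number from compound 2 to compound 3 (0.19 log units; within the scatter). Compound 1, which already carries the 4-hydroxyphenyl group but a 2-fluorophenyl group in place of the trifluoromethyl-bearing ring, gives 8180 nM, again close to compound 3. Taken together, these numbers show that moving the hydroxyl has so far produced no step beyond the scatter in this assay.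

For compound 4 the expected outcome is therefore a number close to that of compound 3, with the step of a 1.2-fold higher number from compound 3 to compound 4 (0.09 log units; within the scatter) estimated to stay within the scatter. The estimate for compound 4 in this assay is 7000 nM, with a likely range from 3500 nM to 14000 nM.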

Compound 4, half-maximal inhibitory concentration: > 50000 nM
Compound 4: no number, only a limit; the forecaster's own chance of this, stated with the estimate: 5%; at least 7.1-fold (0.85 log units) between middle value and limit.
By their numbers in this assay, from the lowest: compounds 3, 1 and 2 (each within the scatter of the next). At a limit, above all of these: compound 4.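

With the 2-(trifluoromethyl)phenyl group in place, the position of the hydroxyl on the ring next to the ring nitrogen clearly matters in this assay: moving it to give the 4-hydroxyphenyl group produces an at least 8.7-fold higher number from compound 3 to compound 4 (0.94 log units; beyond the scatter) and an at least 5.5-fold higher number from compound 2 to compound 4 (0.74 log units; beyond the scatter), whereas the earlier step between the 2-hydroxyphenyl and 3-hydroxyphenyl groups stayed within the scatter. The 4-hydroxyphenyl group does not carry this loss on its own, since with that group held fixed, the change from fluoro to trifluoromethyl gives an at least 6.1-fold higher number from compound 1 to compound 4 (0.78 log units; beyond the scatter), so the large step appears only with the two groups combined. Compound 4 has no number in this assay, only a limit, which means that each of these steps gives a smallest size and not a true one: the limit of > 50000 nM in this assay, at which 1 of the 4 values shown sits.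

The compounds shown do not reveal why this combination behaves so differently, or how far compound 4 really lies from the others. Going by these compounds, it also remains open whether a chloro or methyl group in place of the trifluoromethyl, or an amine in place of the hydroxyl of the 4-hydroxyphenyl group, would give the same result.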